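Adding a second carboxy group to compound 3

A few compounds are considered here, and "the series" means these few. Any claim that something is new, unique, unknown or untested is made for them only; others in the source may bear on it.

In a functional assay on PC-3 cells (Homo sapiens) for antiproliferative activity, read by MTT assay, with a stated time of 24 h (on this read-out lower numbers stand for stronger inhibition and higher numbers for weaker inhibition), compound 1 `CCn1c(C(=O)N[C@@H](CO)C(C)C)ccc1C(CC)(CC)c1ccc(OCS(=O)(=O)c2ccccc2)c(C)c1` gives 10600 nM, compound 2 `CCn1c(C(=O)N[C@@H](C)C(=O)O)ccc1C(CC)(CC)c1ccc(OCS(=O)(=O)c2ccccc2)c(C)c1` gives 16800 nM, and compound 3 `CCn1c(C(=O)N[C@@H](C(=O)O)C(C)C)ccc1C(CC)(CC)c1ccc(OCS(=O)(=O)c2ccccc2)c(C)c1` gives 3070 nM, the lowest of the three numbers. Compound 4 `CCn1c(C(=O)N[C@@H](CCC(=O)O)C(=O)O)ccc1C(CC)(CC)c1ccc(OCS(=O)(=O)c2ccccc2)c(C)c1` carries 1,3-dicarboxypropyl in place of 1-carboxy-2-methylpropyl on an amide-type nitrogen. For the measured compounds named here, two measured steps bear on this change. The step that installs the departing group, a 5.5-fold lower number from compound 2 to compound 3 (0.74 log units; beyond the scatter), is modest and beyond the scatter. The step of a 3.5-fold lower number from compound 1 to compound 3 (0.54 log units; beyond the scatter) is also modest and beyond the scatter. Going by the values given here, no measured step adds a second carboxy group, so the size remains uncertain. A modest upward move is expected, a 2.9-fold higher number from compound 3 to compound 4 (0.47 log units; beyond the scatter). Compound 4 is estimated at 9000 nM, within an expected range from 3500 nM to 25000 nM.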

Compound 4, half-maximal inhibitory concentration: > 50000 nM
Compound 4 ended at the assay's limit (the forecaster's own chance of this, stated with the estimate: 10%); middle value at least 5.5-fold (0.74 log units) away from the limit.
By their numbers in this assay, from the lowest: compound 3; then compounds 1 and 2 (each within the scatter of the next). At a limit, above all of these: compound 4.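

Compound 4 stands at a limit of the assay, not at a number: the limit of > 50000 nM in this assay, at which 1 of the 4 values shown sits. On the amide-type nitrogen, where earlier changes moved the number only modestly, 1,3-dicarboxypropyl in place of 1-carboxy-2-methylpropyl gives a large step, an at least 16-fold higher number from compound 3 to compound 4 (1.21 log units; beyond the scatter). It also lies on the weaker side of the other two side chains, with an at least 2.9-fold higher number from compound 2 to compound 4 (0.47 log units; beyond the scatter) and an at least 4.7-fold higher number from compound 1 to compound 4 (0.67 log units; beyond the scatter). The compounds shown do not separate the effect of the second carboxylic acid from that of losing the 2-methylpropyl branch. Going by these compounds, how a methyl ester or a primary amide would read in place of that second carboxylic acid also remains open.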